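The source may report more compounds than this note shows. Statements on the series, on what has been measured and on what is new or still open speak of the compounds shown alone.

Compound 2 `Cn1c(=O)c(C(=O)NCCCCCCN)c(O)c2ccccc21` stands at the top of the three numbers that have been measured in an assay on isolated protein for inhibition of seed linoleate 13S-lipoxygenase-1 (Glycine max), tested at 0.1 mM (a higher number here means more inhibition at the concentration tested (going by the name of the read-out), a lower number less inhibition), where compound 2 gives 92.1%. Compound 1 `NCCNC(=O)c1c(O)c2ccccc2n(-c2ccccc2)c1=O` lies within the scatter of it, since in this assay compound 1 gives 82.3%, so no order can be read between the two. Compound 3 `NCCCCCCNC(=O)c1c(O)c2ccccc2n(-c2ccccc2)c1=O` is far off, as in this assay compound 3 gives 17.6%.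

The step to compound 4 `Cn1c(=O)c(C(=O)Nc2ccc(N)cc2)c(O)c2ccccc21` is 4-aminophenyl in place of 6-aminohexyl on an amide-type nitrogen. Among the measured compounds shown here, no measured step makes the same swap. The step of a number 64.7 percentage points lower from compound 1 to compound 3 (beyond the scatter) touches the same amide-type nitrogen, but it lengthens a chain rather than exchanging a chain for a ring. The step of a number 74.5 percentage points lower from compound 2 to compound 3 (beyond the scatter) lies on the aromatic nitrogen and does not bear on the amide side at all. Both measured changes were large and downward, which shows that this assay is sensitive to what sits on either nitrogen, yet neither tells what a 4-aminophenyl does in place of a 6-aminohexyl.

Given that, he expects a moderate drop, a number 22.1 percentage points lower from compound 2 to compound 4 (beyond the scatter), with wide uncertainty. His estimate for compound 4 in this assay is 70%, within a range from 30% to 95%.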

Compound 4, a percentage reported as inhibition, at one concentration (the size of the read-out at that concentration, not a potency): 50.8%
Compound 4: middle estimate off by 19.2 percentage points, on the high side; the measured number falls inside the stated range.
By their numbers in this assay, from the lowest: compound 3; then compound 4; then compounds 1 and 2 (each within the scatter of the next).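

The step of a number 41.3 percentage points lower from compound 2 to compound 4 (beyond the scatter) is the first listed exchange of an open chain for an aromatic ring on the amide-type nitrogen, and it shows that in this assay this position responds to the kind of group placed there, not only to chain length as in the earlier step on the same nitrogen. The 6-aminohexyl and the 4-aminophenyl have the same counts of heavy atoms, hydrogen-bond donors and hydrogen-bond acceptors, and neither carries a net charge, so the large fall appears with the ring itself and with no difference in those counts. Nothing measured on these compounds explains the fall.

The compounds shown leave open whether 4-aminophenyl on the amide-type nitrogen would give a similar number with phenyl rather than methyl on the aromatic nitrogen, and whether the chain and ring effects at the two nitrogens add or interact. They also leave open how a plain phenyl without the amine, a benzyl group or an aminocyclohexyl group would compare in that place, which would help separate the contribution of the aromatic ring from that of the amine and its distance from the core.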